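A few compounds are considered here, and "the series" means these few. Any claim that something is new, unique, unknown or untested is made for them only; others in the source may bear on it.

Measured compounds:
- Compound 1 `COc1ccc(-n2nncc2CN2C(=O)C3(C(C#N)=C(N)Oc4c(N)cc5nc6ccccc6nc5c43)c3ccccc32)cc1`. In an ADME assay on HUVEC cells (Homo sapiens) for antiproliferative activity, read by MTT assay, with a stated time of 48 h (a lower number here means a stronger inhibitor, a higher number a weaker inhibitor), compound 1 gives > 50000 nM, which is a limit of the assay, not a number.
- Compound 2 `CCOc1ccccc1-n1nncc1CN1C(=O)C2(C(C#N)=C(N)Oc3c(N)cc4nc5ccccc5nc4c32)c2ccccc21`. In this assay compound 2 gives > 50000 nM, again a limit.
- Compound 3 `N#CC1=C(N)Oc2c(N)cc3nc4ccccc4nc3c2C12C(=O)N(Cc1cnnn1-c1c(F)cccc1F)c1ccccc12`. In this assay compound 3 gives > 50000 nM, also a limit.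

Compound 3 therefore stands nowhere readable on the numbers shown: all three measured values sit at the same limit (the limit of > 50000 nM in this assay, at which 3 of the 3 values shown sit), and none of the compounds can be ordered against another.

Compound 4 `Cc1cc(C)c(-n2nncc2CN2C(=O)C3(C(C#N)=C(N)Oc4c(N)cc5nc6ccccc6nc5c43)c3ccccc32)c(C)c1` is not yet measured. Its change from compound 3 is 2,4,6-trimethylphenyl in place of 2,6-difluorophenyl on an aromatic nitrogen.

The steps between the measured compounds that bear on this change are all those that swap the aryl group on the aromatic nitrogen: a step that the two limits leave unreadable from compound 1 to compound 2, a step that the two limits leave unreadable from compound 1 to compound 3 and a step that the two limits leave unreadable from compound 2 to compound 3. Each of them is unreadable in size, since both ends sit at the limit, so the only thing they show is that three different aryl groups at this position all leave activity at or beyond the limit.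

For compound 4 the expectation is therefore a value at or beyond the same limit, with the step from compound 3 estimated as a step that the limit leaves unreadable from compound 3 to compound 4. The estimate for compound 4 in this assay is 80000 nM, expected to fall between 30000 nM and 300000 nM.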

Compound 4, half-maximal inhibitory concentration: > 50000 nM
Compound 4: only a limit was reported; the forecaster's own chance of this, stated with the estimate: 85%; the middle value does not contradict the limit.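

In this assay, for the compounds shown here, compound 4 gives > 50000 nM, a limit and not a number, so no step between compound 4 and compound 1, compound 2 or compound 3 can be read. The compounds shown leave open whether any other aryl group on this aromatic nitrogen, or any change to the shared core, would give a readable value, since all four sit together: the limit of > 50000 nM in this assay, at which 4 of the 4 values shown sit.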